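A few compounds are considered here, and "the series" means these few. Any claim that something is new, unique, unknown or untested is made for them only; others in the source may bear on it.

Compound 1 `c1ccc(-c2ccc(Cn3nnc4ccccc43)cc2)cc1`: 7.9 mL/min/g
Compound 2 `Fc1ccc(-c2ccc(Cn3nnc4ccccc43)cc2)c(F)c1`: 0.9 mL/min/g
Compound 3 `Fc1ccc(-c2ccc(Cn3nnc4ccccc43)cc2)c(Cl)c1`: 0.7 mL/min/g

Of the compounds shown here, three sharing one core have been measured in an ADME assay on microsomes from liver (Homo sapiens) for metabolic stability, tested at 2.5 uM; a lower number here means slower removal, a higher number faster removal of the compound. Compound 1, the parent with an unsubstituted phenyl, stands at the high end. Adding two halogens to that ring brought the number down in both cases: an 8.8-fold lower number from compound 1 to compound 2 (0.94 log units; beyond the scatter) and an 11-fold lower number from compound 1 to compound 3 (1.05 log units; beyond the scatter). Compound 3 thus sits at the low end of the numbers shown, far from compound 1, while the remaining step, a 1.3-fold lower number from compound 2 to compound 3 (0.11 log units; within the scatter), is within the scatter.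

Compound 4 `Clc1ccc(-c2ccc(Cn3nnc4ccccc43)cc2)c(Cl)c1` has not yet been measured. It differs from compound 3 in one place: chloro in place of fluoro on an aromatic carbon. Among the compounds with values here, the only measured step that bears on this kind of change is the one from compound 2 to compound 3, where the same swap at the other position gave a 1.3-fold lower number from compound 2 to compound 3 (0.11 log units; within the scatter), a step within the scatter. On that basis no step beyond the scatter is expected in this assay, and compound 4 is estimated at 0.6 mL/min/g (range 0.3 mL/min/g to 1.2 mL/min/g), meaning an expected step of a 1.2-fold lower number from compound 3 to compound 4 (0.07 log units; within the scatter).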

Compound 4, intrinsic clearance in a liver preparation (reported as CLH), per the amount of preparation that the assay uses: 0.6 mL/min/g
Estimate against measurement, compound 4: no gap at the digits printed, and the stated range covers the measured number.
By their numbers in this assay, from the lowest: compounds 4, 3 and 2 (each within the scatter of the next); then compound 1.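

In this assay, chloro in place of fluoro at the position para to a large group, turning 2-chloro-4-fluorophenyl into 2,4-dichlorophenyl, leaves the result within the scatter (a 1.2-fold lower number from compound 3 to compound 4 (0.07 log units; within the scatter)), so this position accepts either halogen without a readable change. Exchanging both halogens of the 2,4-difluorophenyl compound also stays within the scatter (a 1.5-fold lower number from compound 2 to compound 4 (0.18 log units; within the scatter)), while the 2,4-dichlorophenyl compound stands well apart from the unsubstituted parent (a 13-fold lower number from compound 1 to compound 4 (1.12 log units; beyond the scatter)), so all three dihalogenated compounds now share that separation. Nothing measured here gives a reason for these numbers.

From the compounds shown here alone, in every step from the parent both halogens enter together, so the share of each position remains unknown, and a single chloro or fluoro could settle it. Also open, going by these compounds, is whether a non-halogen group at this position, such as a methoxy group, a nitrile or an amine, would give a number like these.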